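Does One Fluoro Group Matter for Kinase Inhibition?

The source may report more compounds than this note shows. Statements on the series, on what has been measured and on what is new or still open speak of the compounds shown alone.

Measured so far:
compound 1 `Cc1c(C(=O)Nc2ccc(Oc3ncnc4[nH]cc(-c5ccccc5)c34)c(F)c2)c(=O)c2ccccc2n1C`: > 10000 nM (a limit of the assay)
compound 2 `Cc1c(C(=O)Nc2ccc(Oc3ncnc4[nH]cc(-c5ccccc5)c34)c(F)c2)c(=O)c2cc(F)ccc2n1C`: > 10000 nM (a limit of the assay)
compound 3 `CCc1ccc2c(c1)c(=O)c(C(=O)Nc1ccc(Oc3ncnc4[nH]cc(-c5ccccc5)c34)cc1F)c(C)n2C`: 30 nM

All three were tested in an assay on isolated protein for inhibition of tyrosine-protein kinase receptor UFO (Homo sapiens), read by FRET and Z'-LYTE, with a stated time of 1.5 h; a lower number here means a stronger inhibitor, a higher number a weaker inhibitor. For compound 1 the reading > 10000 nM is a limit of the assay rather than a number. For compound 2 the reading > 10000 nM is likewise a limit. Compound 3 alone gives a number, 30 nM.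

Compound 2 and compound 1 differ in one place, (hydrogen in place of fluoro on an aromatic carbon). The step that the two limits leave unreadable from compound 2 to compound 1 has no readable size, as the limit of > 10000 nM in this assay, at which 2 of the 3 values shown sit, shows. Compound 3 and compound 2 differ in more than one place; the difference between the two cores is not broken down here.

Compound 4 `CCc1ccc2c(c1)c(=O)c(C(=O)Nc1ccc(Oc3ncnc4[nH]cc(-c5ccccc5)c34)cc1)c(C)n2C` is not yet measured. It relates to compound 3 by hydrogen in place of fluoro on an aromatic carbon, the same kind of change as that from compound 2 to compound 1, but the place differs: there the fluoro sat on a ring that is part of a fused or bridged system of two rings, meta to a fused ring and para to a fused ring, whereas here it sits ortho to a large group and meta to a large group.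

The measured step offers no size, so the expectation rests on compound 3 and its value 30 nM. For compound 4 the expected step is a 2.0-fold higher number from compound 3 to compound 4 (0.30 log units; within the scatter). Compound 4 is thus estimated at 60 nM, with a likely range from 20 nM to 250 nM.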

Compound 4, half-maximal inhibitory concentration: 105 nM
For compound 4 the middle estimate is 1.8-fold (0.24 log units) below the measured one; low and high end bracket the measured number.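

In this assay, putting hydrogen in place of the fluoro on an aromatic carbon, ortho to a large group and meta to a large group, gives a 3.5-fold higher number from compound 3 to compound 4 (0.54 log units; beyond the scatter), so on this core the fluoro goes with modestly stronger inhibition. The same kind of change on the other core, from compound 2 to compound 1, cannot be read, because both compounds sit at a limit of the assay rather than at a number: the limit of > 10000 nM in this assay, at which 2 of the 4 values shown sit. The two steps therefore cannot be compared, and since the fluoro also sits in a different place in each pair, this result does not show whether the change carries from one core to the other.

The compounds shown leave open whether a chloro or a methoxy group on the same carbon would match the fluoro of compound 3. They also leave open what separates the two cores, as compound 2 and compound 3 differ in more than one place.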